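The source may report more compounds than this note shows. Statements on the series, on what has been measured and on what is new or still open speak of the compounds shown alone.

Of the compounds shown here, three sharing one core have been measured in a functional assay on the whole organism (Tail, strain ICR) with Mus musculus as the target, in the tail flick test, with a stated time of 150 min, at a dose of 25 umol/kg by the oral route; on this read-out higher numbers stand for a stronger effect at the one dose given and lower numbers for a weaker effect. Compound 1 `O=C(CN(c1ncnc2c1ncn2C1CCCCO1)C1CC1)N[C@@H](CCC(=O)OCc1ccccc1)C(=O)OCc1ccccc1` gives 14.1%. Compound 2 `CC[C@H](C)[C@H](NC(=O)CN(c1ncnc2c1ncn2C1CCCCO1)C1CC1)C(=O)OCc1ccccc1` gives 16.4%, and compound 3 `O=C(CN(c1ncnc2c1ncn2C1CCCCO1)C1CC1)N[C@@H](CO)C(=O)OCc1ccccc1` gives 18.3%. Compound 3 holds the highest of the three numbers, yet the step of a number 1.9 percentage points higher from compound 2 to compound 3 (within the scatter) and the step of a number 4.2 percentage points higher from compound 1 to compound 3 (within the scatter) both lie within the scatter, so on these numbers the three compounds cannot be told apart.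

Compound 4 `O=C(CN(c1ncnc2c1ncn2C1CCCCO1)C1CC1)N[C@@H](CC(=O)OCc1ccccc1)C(=O)OCc1ccccc1` has not yet been measured. Compared with compound 3 it carries benzyloxycarbonyl in place of hydroxy on a saturated chain carbon, two bonds along the chain from an amide-type nitrogen and a carbonyl carbon. The measured change most closely related to this one is the exchange at the same place between compound 1 and compound 3, where a group of the same kind was removed rather than added; that step gave a number 4.2 percentage points higher from compound 1 to compound 3 (within the scatter). The exchange on a saturated chain carbon bound to an amide-type nitrogen and a carbonyl carbon gave a number 2.3 percentage points higher from compound 1 to compound 2 (within the scatter), equally small. Within the data shown here, no measured step here lies beyond the scatter, so for compound 4 a step of about a number 3.3 percentage points lower from compound 3 to compound 4 (within the scatter) is expected, meaning no change beyond the scatter. Compound 4 is therefore estimated to give 15% in this assay, within a range from 8% to 22%.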

Compound 4, a percentage reported as activity, at one dose (the size of the read-out at that dose, not a potency): 0.06%
For compound 4 the middle estimate is 14.9 percentage points above the measured one, outside the stated range (below it).
By their numbers in this assay, from the lowest: compound 4; then compounds 1, 2 and 3 (each within the scatter of the next).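

Among these compounds, at this position the side chain is not as interchangeable as the first three compounds suggested: in this assay, replacing hydroxy with benzyloxycarbonyl gives a number 18.2 percentage points lower from compound 3 to compound 4 (beyond the scatter), and replacing sec-butyl with (benzyloxycarbonyl)methyl gives a number 16.3 percentage points lower from compound 2 to compound 4 (beyond the scatter), the first steps here to exceed the usual variation. The benzyloxycarbonyl group alone does not go with the loss, since compound 1 carries it too on a longer chain, and shortening that chain gives a number 14 percentage points lower from compound 1 to compound 4 (beyond the scatter), so the result depends on where the group sits and not only on its presence. No supporting measurement explains why this shorter chain behaves so differently.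

A carboxylic acid or an amine at the end of the same chain, or a chain longer than that of compound 1, would help show whether the loss is tied to this one chain length or to the benzyloxycarbonyl group placed there. As far as these compounds go, with a single dose and a single time, it also remains open whether compound 4 would show an effect at a higher dose or at another time.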